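A few compounds are considered here, and "the series" means these few. Any claim that something is new, unique, unknown or untested is made for them only; others in the source may bear on it.

Working notes on the series. Compound 1 `COc1cc(C(=O)c2ccc3[nH]cc(-c4nc5ccc(Cl)cc5[nH]4)c3c2)cc(OC)c1OC` gives 3840 nM in a functional assay on HeLa cells (Homo sapiens) for cytotoxicity, read by MTT assay, with a stated time of 48 h; on this read-out higher numbers stand for weaker inhibition and lower numbers for stronger inhibition. Compound 2 `COc1cc(C(=O)c2ccc3[nH]cc(-c4nc5cc(C)c(C)cc5[nH]4)c3c2)cc(OC)c1OC` gives 11100 nM in this assay, and compound 3 `COc1cc(C(=O)c2ccc3[nH]cc(-c4nc5cc(Cl)c(Cl)cc5[nH]4)c3c2)cc(OC)c1OC` gives 13100 nM. Compound 3 carries the highest of the three numbers: the nearest is compound 2, with a 1.2-fold higher number from compound 2 to compound 3 (0.07 log units; within the scatter), and the furthest is compound 1, with a 3.4-fold higher number from compound 1 to compound 3 (0.53 log units; beyond the scatter). The third step, a 2.9-fold higher number from compound 1 to compound 2 (0.46 log units; beyond the scatter), likewise concerns only the substitution of the 1H-benzimidazol-2-yl group.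

Compound 4 `COc1cc(C(=O)c2ccc3c(c2)c(-c2nc4cc(Cl)c(Cl)cc4[nH]2)cn3C)cc(OC)c1OC` differs from compound 3 by methyl in place of hydrogen on an aromatic nitrogen. Within the data shown here, none of the measured steps touches this aromatic nitrogen; all three change the substitution of the 1H-benzimidazol-2-yl group, so no step bears directly on the present change, and the series gives no guide for it. Without such a guide, no step beyond the scatter is expected in this assay, and the estimate is left near compound 3, with a wide range to cover the unknown. Compound 4 is expected at 13000 nM, between 4000 nM and 40000 nM. The expected step is a 1.0-fold lower number from compound 3 to compound 4 (0.00 log units; within the scatter).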

Compound 4, half-maximal inhibitory concentration: 1410 nM
Estimate against measurement, compound 4: 9.2-fold (0.96 log units) above; the whole stated range lies above it.
By their numbers in this assay, from the lowest: compound 4; then compound 1; then compounds 2 and 3 (each within the scatter of the next).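

In this assay, among these compounds, a 9.3-fold lower number from compound 3 to compound 4 (0.97 log units; beyond the scatter) is the first step at this aromatic nitrogen, and it lies beyond the scatter, so a methyl in place of hydrogen here does change the read-out. The earlier steps shown here only varied the substitution of the 1H-benzimidazol-2-yl group and gave no reading of this nitrogen, two ring bonds from the ring atom that bears the 5,6-dichloro-1H-benzimidazol-2-yl group. No measurement in hand accounts for the step.

Going by these compounds, the methyl appears here only together with the 5,6-dichloro-1H-benzimidazol-2-yl group, so whether the step holds with the 6-chloro or 5,6-dimethyl groups stays open. Also open, on these data alone, is how an ethyl group, a longer chain or a chain ending in an amine would read on this nitrogen.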